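Adding a sulfanyl group to compound 2

A few compounds are considered here, and "the series" means these few. Any claim that something is new, unique, unknown or untested is made for them only; others in the source may bear on it.

In an ADME assay on the whole organism (strain Sprague-Dawley) for pharmacokinetics, with Rattus norvegicus as the target, read by HPLC, at a dose of 1 mg/kg by the subcutaneous route (on this read-out higher numbers stand for wider distribution into tissues and lower numbers for narrower distribution), compound 1 (`O=C(Nc1nc2ccccc2s1)c1ccc(OC(F)F)c(OCC2CC2)c1`) gives 0.0177 L/kg and compound 2 (`O=C(Nc1ccc2ncsc2c1)c1ccc(OC(F)F)c(OCC2CC2)c1`) gives 0.0196 L/kg as its value, so compound 2 stands within the scatter of compound 1. Compound 3 (`O=C(Nc1ccc2nc(S)sc2c1)c1ccc(OC(F)F)c(OCC2CC2)c1`) differs from compound 2 by sulfanyl in place of hydrogen on an aromatic carbon. Among the measured compounds shown here, only one measured step bears on this: a 1.1-fold higher number from compound 1 to compound 2 (0.04 log units; within the scatter) with 1,3-benzothiazol-6-yl in place of 1,3-benzothiazol-2-yl on an amide-type nitrogen. That step involves no sulfanyl group, so it offers only loose guidance. In this assay the expected step is a 1.0-fold higher number from compound 2 to compound 3 (0.01 log units; within the scatter) and none beyond the scatter is expected. For compound 3 the estimate is 0.02 L/kg with values between 0.01 L/kg and 0.045 L/kg as its expected range.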

Compound 3, volume of distribution: 0.0305 L/kg
Beside the measured number, compound 3's estimate is 1.5-fold (0.18 log units) below it, and the stated range covers the measured number.
By their numbers in this assay, from the lowest: compounds 1, 2 and 3 (each within the scatter of the next).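

In this assay, putting sulfanyl on the aromatic carbon next to the ring nitrogen and next to the ring sulfur gives a 1.6-fold higher number from compound 2 to compound 3 (0.19 log units; within the scatter). The earlier step only moved the point where the amide nitrogen joins the ring system, whereas this one adds a group to the five-membered aromatic ring itself, and the change stays within the scatter. No measurement here explains this result. From the compounds shown here alone, whether an amine or a carboxylic acid on this same carbon would give a step beyond the scatter stays open.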